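A third methoxy group on compound 3

This account rests on a few compounds, and the source may have more. Where it says the series, first, only, none or still open, it means among the compounds named here.

In a functional assay on MCF7 cells (Homo sapiens) for antiproliferative activity, read by MTT assay, with a stated time of 48 h (a lower number here means a stronger inhibitor, a higher number a weaker inhibitor), compound 3 (`COc1ccc(C2=N/C(=C\c3cc(Br)cc(Br)c3OC(C)=O)C(=O)n3c(C)nc(=S)n32)cc1OC`) gives 6840 nM and compound 1 (`COc1ccc(C2=N/C(=C\c3cc(Br)cc(Br)c3OC(C)=O)C(=O)NN2C(N)=S)cc1OC`) gives 13400 nM as values that lie within the usual scatter of each other. Compound 2 (`CC(=O)Oc1c(Br)cc(Br)cc1/C=C1\N=C(c2ccccc2)n2c(=S)nc(C)n2C1=O`) reads > 100000 nM as a limit of the assay and not a number. Going from phenyl to 3,4-dimethoxyphenyl gave a large step (an at least 14-fold lower number from compound 2 to compound 3 (1.16 log units; beyond the scatter)), the only measured one that bears on compound 4 (`COc1cc(C2=N/C(=C\c3cc(Br)cc(Br)c3OC(C)=O)C(=O)n3c(C)nc(=S)n32)cc(OC)c1OC`). Compound 4 carries methoxy in place of hydrogen on an aromatic carbon, so 3,4-dimethoxyphenyl becomes 3,4,5-trimethoxyphenyl. Given that earlier step (an at least 14-fold lower number from compound 2 to compound 3 (1.16 log units; beyond the scatter)), a further move to a lower number is expected in this assay but a much smaller one, possibly within the scatter. The expected value for compound 4 is 4500 nM (range 1500 nM to 14000 nM). That would be an expected change (a 1.5-fold lower number from compound 3 to compound 4 (0.18 log units; within the scatter)).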

Compound 4, half-maximal inhibitory concentration: 3070 nM
Compound 4: the middle estimate sits 1.5-fold (0.17 log units) above what was measured, and the stated range covers the measured number.
By their numbers in this assay, from the lowest: compound 4; then compounds 3 and 1 (each within the scatter of the next). At a limit, above all of these: compound 2.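

In this assay a further substituent on this ring still moves the number: methoxy in place of hydrogen on the aromatic carbon ortho to a methoxy group gives a modest step beyond the scatter (a 2.2-fold lower number from compound 3 to compound 4 (0.35 log units; beyond the scatter)). Against plain phenyl, 3,4,5-trimethoxyphenyl gives a large step (an at least 32-fold lower number from compound 2 to compound 4 (1.51 log units; beyond the scatter)). Compound 2 stands at a limit and not a number: the limit of > 100000 nM in this assay, at which 1 of the 4 values shown sits.

The compounds shown leave open whether fluorine or a longer chain such as ethoxy would serve on this carbon as well as methoxy. On these data alone, it also remains open whether this third methoxy group would lower the number on the core of compound 1.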